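The source may hold more compounds than are shown below. What is called first, only, known or untested is meant among the compounds shown, and "the series" means these compounds.

Measured so far:
compound 1, `COc1cc2c(cc1OC)C(CC(=O)Nc1ccc(Br)cc1)CC2`, 40%
compound 2, `COc1cc2c(cc1OC)C(CC(=O)Nc1ccccc1C)CC2`, 18%

For the measured compounds named here, in a functional assay on the whole organism (strain Wistar) for inhibition, with Rattus norvegicus as the target, read by paw edema, with a stated time of 2 h, at a dose of 100 mg/kg (on this read-out higher numbers stand for more inhibition at the one dose given (going by the name of the read-out) and lower numbers for less inhibition), compound 1 gives 40%, while compound 2 gives 18%, so compound 2 stands lowest of the two numbers, with compound 1 the only neighbour. Going by the values given here, the one step in this assay is a number 22 percentage points lower from compound 1 to compound 2 (beyond the scatter); it swaps the whole aryl group on the amide-type nitrogen and says nothing about one substituent exchanged for another on an otherwise unchanged ring.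

Compound 3, `COc1ccccc1NC(=O)CC1CCc2cc(OC)c(OC)cc21`, is not yet measured. It differs from compound 2 as follows: methoxy in place of methyl on an aromatic carbon. The place is an aromatic carbon of a six-membered aromatic ring of carbon only, ortho to a large group. Among the compounds with values here, no measured step bears on this change, since the single step in this assay concerns a different kind of exchange. Within the data shown here, the expectation for the step is therefore a number 2 percentage points higher from compound 2 to compound 3 (within the scatter), that is, no movement beyond the scatter, because the only anchor is compound 2 at 18%. Compound 3 is estimated at 20% in this assay, within 5% to 40%.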

Compound 3, a percentage reported as inhibition, in the whole organism at one dose (the size of the read-out at that dose, not a potency): 16%
Compound 3: the middle estimate sits 4 percentage points above what was measured; measured number inside the range.
By their numbers in this assay, from the lowest: compounds 3 and 2 (each within the scatter of the next); then compound 1.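

In this assay, for the compounds shown here, the step from methyl to methoxy is the first exchange of one substituent on an otherwise unchanged ring, and it reads a number 2 percentage points lower from compound 2 to compound 3 (within the scatter). At this aromatic carbon, ortho to a large group, the extra oxygen and the hydrogen-bond acceptor that enter with methoxy therefore bring no change beyond the scatter in paw edema inhibition at the one dose given. Against compound 1 the picture repeats: the exchange of the whole aryl group reads a number 24 percentage points lower from compound 1 to compound 3 (beyond the scatter) and the earlier one reads a number 22 percentage points lower from compound 1 to compound 2 (beyond the scatter), so both the 2-methylphenyl and the 2-methoxyphenyl amides stand apart from the 4-bromophenyl amide, and no compound shown goes against this. No independent measurement accompanies these numbers to account for them.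

The three compounds do not separate the identity of the bromine from its place on the ring, as 4-bromophenyl differs from both other aryl groups in substituent and in place at once. From the compounds shown here alone, it also remains open whether an amine or a carboxylic acid on the same aromatic carbon, ortho to a large group, would move the number beyond the scatter, given that methyl and methoxy do not differ there.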